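The compounds below may be only part of what the source reports. "The series", "measured", "known", "first", "only" and "open" are said of these compounds alone.

Measured compounds in a functional assay on HepG2 cells (Homo sapiens) for antiproliferative activity, read by MTT assay; a higher number here means a weaker inhibitor, a lower number a stronger inhibitor:
- compound 1 `COc1ccc(-c2ccnc(Nc3cccc(OC)c3)n2)cc1` gives 13900 nM
- compound 2 `Clc1ccc(Nc2nccc(-c3ccc(Br)cc3)n2)cc1` gives 47500 nM
- compound 3 `COc1ccc(-c2ccnc(Nc3ccc(Cl)cc3)n2)cc1` gives 4500 nM

Compound 4 `COc1cccc(Nc2nccc(-c3ccc(Br)cc3)n2)c1` is not yet measured. It differs from compound 1 by bromo in place of methoxy on an aromatic carbon. The same change, from compound 3 to compound 2, is bromo in place of methoxy on an aromatic carbon and gave an 11-fold higher number from compound 3 to compound 2 (1.02 log units; beyond the scatter). The two place lines read the same word for word, so the change is taken as the same. The difference between the core of compound 1 and the core of compound 3 is not broken down here; compound 1 stands between compound 3 and compound 2 in this assay.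

Compound 4 is expected to follow the earlier step, giving an estimated 7.2-fold higher number from compound 1 to compound 4 (0.86 log units; beyond the scatter), because the same change produced an 11-fold higher number from compound 3 to compound 2 (1.02 log units; beyond the scatter). The estimate for compound 4 in this assay is 100000 nM, expected between 30000 nM and 300000 nM.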

Compound 4, half-maximal inhibitory concentration: 148000 nM
Estimate against measurement, compound 4: 1.5-fold (0.17 log units) below; low and high end bracket the measured number.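

In this assay bromo in place of methoxy on an aromatic carbon gives an 11-fold higher number from compound 1 to compound 4 (1.03 log units; beyond the scatter) and the step carries over from one core to the other with no difference in size: the same change on two cores in this assay, an 11-fold higher number (1.02 log units; beyond the scatter) from compound 3 to compound 2 and an 11-fold higher number (1.03 log units; beyond the scatter) from compound 1 to compound 4, 1.0-fold (0.00 log units) apart, within the scatter of two such steps

This rests on two matched pairs in one assay, so it shows transfer between the core of compound 1 and the core of compound 3 and not across the series as a whole. It does not show why the change weakens these compounds, or whether any other change would carry over as cleanly.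

Still open, on these data alone, is how an amine, a carboxylic acid or a longer alkoxy chain on that aromatic carbon would compare with methoxy and bromo. Also open, as far as these compounds go, is whether the step holds on a core that carries neither the chloro group of compound 3 nor the second methoxy group of compound 1.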